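The source may report more compounds than this note shows. Statements on the series, on what has been measured and on what is new or still open speak of the compounds shown alone.

Measured so far:
compound 1 `O=C(Nc1cccc(-n2cc(-c3ccncc3)c(-c3ccc(Cl)c(O)c3)n2)c1)Nc1cccc(C(F)(F)F)c1` gives 22500 nM in a functional assay on PC-3 cells (Homo sapiens) for inhibition, read by sulforhodamine B assay, with a stated time of 48 h; on this read-out higher numbers stand for weaker inhibition of growth and lower numbers for stronger inhibition of growth;
compound 2 `COc1cc(-c2nn(-c3cccc(NC(=O)Nc4ccc(Cl)c(Cl)c4)c3)cc2-c2ccncc2)ccc1Cl` gives 2830 nM in this assay.

Compound 2 holds the lower of the two numbers, and compound 1 lies beyond the scatter above it; since the two differ in more than one place, their gap is not a single step. Compound 3 `COc1cc(-c2nn(-c3cccc(NC(=O)Nc4cccc(C(F)(F)F)c4)c3)cc2-c2ccncc2)ccc1Cl` follows from compound 2 by 3-(trifluoromethyl)phenyl in place of 3,4-dichlorophenyl on an amide-type nitrogen. Compound 1 carries the same trifluoromethylphenyl group and gives the weaker number, though alongside a second difference, so a modest loss is expected from compound 2 to compound 3, roughly a 1.9-fold higher number from compound 2 to compound 3 (0.29 log units; within the scatter). Compound 3 is estimated at 5500 nM, within 2000 nM to 16000 nM.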

Compound 3, concentration for total growth inhibition: 2510 nM
Estimate against measurement, compound 3: 2.2-fold (0.34 log units) above; low and high end bracket the measured number.
By their numbers in this assay, from the lowest: compounds 3 and 2 (each within the scatter of the next); then compound 1.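

In this assay, replacing 3,4-dichlorophenyl with 3-(trifluoromethyl)phenyl on the amide-type nitrogen gives a 1.1-fold lower number from compound 2 to compound 3 (0.05 log units; within the scatter) so this position accepts either aryl group with no readable change. Methyl in place of hydrogen on the oxygen on the aromatic ring gives a 9.0-fold lower number from compound 1 to compound 3 (0.95 log units; beyond the scatter) and this isolates the gap between compound 1 and compound 3 as a single change at that oxygen. Nothing at hand gives a cause for either step.

As far as these compounds go, it remains open how a longer chain such as ethyl on that oxygen, or an amine in place of the oxygen, would read. From the compounds shown here alone, a nitrile on the phenyl ring at the amide-type nitrogen is equally open.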